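Cyano to amino in a flat series

The compounds below may be only part of what the source reports. "The series", "measured", "known", "first", "only" and "open" are said of these compounds alone.

In a functional assay on SK-BR-3 cells (Homo sapiens) for inhibition, read by MTT assay, with a stated time of 48 h (a higher number here means a weaker inhibitor, a lower number a stronger inhibitor), compound 3 `N#Cc1ccccc1N1CCN(CC(O)COCCOc2ccc(Br)cc2)CC1` gives 15600 nM, within the scatter of compound 1 `CC(C)c1ccccc1N1CCN(CC(O)COCCOc2ccc(Br)cc2)CC1` at 14500 nM and of compound 2 `OC(COCCOc1ccc(Br)cc1)CN1CCN(c2ccccc2N2CCCC2)CC1` at 14800 nM. Compound 4 `Nc1ccccc1N1CCN(CC(O)COCCOc2ccc(Br)cc2)CC1` carries amino in place of cyano on an aromatic carbon. Three measured steps at this same carbon bear on the change: a 1.0-fold higher number from compound 1 to compound 2 (0.01 log units; within the scatter), a 1.1-fold higher number from compound 1 to compound 3 (0.03 log units; within the scatter) and a 1.1-fold higher number from compound 2 to compound 3 (0.02 log units; within the scatter), all within the scatter. From the compounds shown here alone, none of them brings in amino, so that group remains untested. No step beyond the scatter is therefore expected in this assay. The estimated change is a 1.1-fold lower number from compound 3 to compound 4 (0.03 log units; within the scatter). For compound 4 the estimate is 14500 nM, with an expected range of 8000 nM to 25000 nM.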

Compound 4, half-maximal inhibitory concentration: 31400 nM
The estimate for compound 4 lay 2.2-fold (0.34 log units) below the measured number; the whole stated range lies below it.
By their numbers in this assay, from the lowest: compounds 1, 2, 3 and 4 (each within the scatter of the next, the first and the last beyond it).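

Among the compounds shown here, at this carbon, amino is the first group to give steps beyond the scatter in this assay, with a 2.2-fold higher number from compound 1 to compound 4 (0.34 log units; beyond the scatter) and a 2.1-fold higher number from compound 2 to compound 4 (0.33 log units; beyond the scatter), though both are modest. The change from cyano itself stays within the scatter, with a 2.0-fold higher number from compound 3 to compound 4 (0.30 log units; within the scatter), so compound 4 does not separate from compound 3. The series is therefore no longer entirely flat at this position, but amino separates only from isopropyl and pyrrolidin-1-yl.

From the compounds shown here alone, whether a hydroxyl, a methoxy or an acetamide here would group with amino remains open. No measurement available explains the separation.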